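This account rests on a few compounds, and the source may have more. Where it says the series, first, only, none or still open, it means among the compounds named here.

Measured compounds:
- compound 1 `O=C(c1ccccc1)c1ccn(-c2ccc3c(c2)B(O)OC3)c1`: > 10 ug/mL in an ADME assay on L929 cells (Mus musculus) for cytotoxicity, read by resazurin assay, with a stated time of 72 h (a higher number here means a weaker inhibitor, a lower number a stronger inhibitor), a limit of the assay, not a number
- compound 2 `O=C(c1ccc(Cl)cc1)c1ccn(-c2ccc3c(c2)B(O)OC3)c1`: > 10 ug/mL in this assay, likewise a limit
- compound 3 `O=C(CCc1ccccc1)c1ccn(-c2ccc3c(c2)B(O)OC3)c1`: > 10 ug/mL in this assay, likewise a limit

Compound 3 therefore stands only at a limit, as stated by the limit of > 10 ug/mL in this assay, at which 3 of the 3 values shown sit. The three measured steps, a step that the two limits leave unreadable from compound 1 to compound 2, a step that the two limits leave unreadable from compound 1 to compound 3 and a step that the two limits leave unreadable from compound 2 to compound 3, give no readable size, so none of them can be used to gauge the next change.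

The unmeasured compound 4 `O=C(c1ccn(-c2ccc3c(c2)B(O)OC3)c1)C1CCCCC1` differs from compound 3 by cyclohexyl in place of phenethyl on a carbonyl carbon. Going by the values given here, no measured step bears on this change. On the three limits shown, compound 4 is expected to remain at or near the limit in this assay, with an expected step that the limit leaves unreadable from compound 3 to compound 4. The estimate for compound 4 is 20 ug/mL, in the range 8 ug/mL to 60 ug/mL.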

Compound 4, half-maximal inhibitory concentration: > 10 ug/mL
Compound 4: no number, only a limit (the forecaster's own chance of this, stated with the estimate: 80%); the middle value lies beyond the limit too.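

Compound 4 in this assay gives only a limit, so its steps from compound 1, compound 2 and compound 3 cannot be read: the limit of > 10 ug/mL in this assay, at which 4 of the 4 values shown sit. The compounds shown leave open whether any group on the carbonyl carbon changes the read-out, and by how much.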